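The compounds below may be only part of what the source reports. "The series", "measured", "known", "first", "only" and "open" are said of these compounds alone.

Measured compounds and their values in a functional assay on PC-3 cells (Homo sapiens) for cytotoxicity, read by MTT assay, with a stated time of 72 h; on this read-out lower numbers stand for stronger inhibition and higher numbers for weaker inhibition:

compound 1, `COc1ccc(/C=N/NC(=O)Nc2cc3c(Nc4ccc(F)c(Cl)c4)ncnc3cc2O[C@H]2CCOC2)cc1`, 34100 nM

compound 2, `COc1ccc(/C=N/NC(=O)Nc2cc3c(Nc4ccc(F)c(Cl)c4)ncnc3cc2O[C@H]2CCOC2)c(OC)c1OC`, 25600 nM

compound 3, `COc1ccc(/C=N/NC(=O)Nc2cc3c(Nc4ccc(F)c(Cl)c4)ncnc3cc2OC)cc1`, 16500 nM

Compound 2 is derived from compound 1 by one change, (2,3,4-trimethoxyphenyl in place of 4-methoxyphenyl on a carbon with a double bond to nitrogen), and this step, a 1.3-fold lower number from compound 1 to compound 2 (0.12 log units; within the scatter), did not move the read-out beyond what repeated runs of this assay can differ by. Compound 3 is derived from compound 1 by a different single change, (methyl in place of oxolan-3-yl on an oxygen on an aromatic ring), and that step, a 2.1-fold lower number from compound 1 to compound 3 (0.32 log units; beyond the scatter), is a modest one. Compound 3 has the lowest of the three numbers, though against compound 2 the gap is within the scatter.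

Compound 4, `COc1cc2ncnc(Nc3ccc(F)c(Cl)c3)c2cc1NC(=O)N/N=C/c1ccc(OC)c(OC)c1OC`, has not yet been measured. It differs from compound 3 by 2,3,4-trimethoxyphenyl in place of 4-methoxyphenyl on a carbon with a double bond to nitrogen, which is the same change that separates compound 1 from compound 2, made here on the core of compound 3 rather than on the core of compound 1. The step from compound 3 to compound 4 is expected to resemble the one already seen, so a step of about a 1.3-fold lower number from compound 3 to compound 4 (0.10 log units; within the scatter) is estimated, resting on the earlier step of a 1.3-fold lower number from compound 1 to compound 2 (0.12 log units; within the scatter). Compound 4 is therefore expected to give roughly 13000 nM in this assay.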

Compound 4, half-maximal inhibitory concentration: 29300 nM
The estimate for compound 4 lay 2.3-fold (0.35 log units) below the measured number; the whole stated range lies below it.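

In this assay, putting 2,3,4-trimethoxyphenyl in place of 4-methoxyphenyl on the core of compound 3 gave a 1.8-fold higher number from compound 3 to compound 4 (0.25 log units; within the scatter), and putting methyl in place of oxolan-3-yl on the trimethoxyphenyl side gave a 1.1-fold higher number from compound 2 to compound 4 (0.06 log units; within the scatter). The trimethoxyphenyl change cannot be told apart on its two cores: the same change on two cores in this assay, a 1.3-fold lower number (0.12 log units; within the scatter) from compound 1 to compound 2 and a 1.8-fold higher number (0.25 log units; within the scatter) from compound 3 to compound 4, 2.4-fold (0.37 log units) apart, within the scatter of two such steps The methyl change cannot be told apart either, so nothing here shows that the core alters these steps, yet a single pair of small steps per change does not prove that either change carries over unaltered: the same change on two cores in this assay, a 2.1-fold lower number (0.32 log units; beyond the scatter) from compound 1 to compound 3 and a 1.1-fold higher number (0.06 log units; within the scatter) from compound 2 to compound 4, 2.4-fold (0.37 log units) apart, within the scatter of two such steps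

The compounds shown leave open whether an amine or a carboxylic acid on the phenyl ring, or a longer chain in place of the methyl on the oxygen, would move the read-out beyond the scatter. They also leave open how these four compounds would compare on any cell line other than the one used here.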